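Moving the carbamate ring attachment on a shared core

A few compounds are considered here, and "the series" means these few. Any claim that something is new, unique, unknown or untested is made for them only; others in the source may bear on it.

Three compounds share one core and differ only in the group on a carbonyl carbon. In an assay on U2OS cells for inhibition of secreted frizzled-related protein 1 (Homo sapiens), read by a luciferase reporter, with a stated time of 18 h (a higher number here means that more compound is needed for the effect, a lower number that less compound is needed), compound 1 `O=C(c1ccc(Cl)nc1)N1CCC(NS(=O)(=O)c2cc(S(=O)(=O)c3ccccc3)ccc2C(F)(F)F)CC1` gives 140 nM, compound 2 `O=C(O)CCCC(=O)N1CCC(NS(=O)(=O)c2cc(S(=O)(=O)c3ccccc3)ccc2C(F)(F)F)CC1` gives 570 nM, and compound 3 `CC(C)(C)OC(=O)N1CCC[C@H]1C(=O)N1CCC(NS(=O)(=O)c2cc(S(=O)(=O)c3ccccc3)ccc2C(F)(F)F)CC1` gives 60 nM, the lowest of the three: the step of a 2.3-fold lower number from compound 1 to compound 3 (0.37 log units; beyond the scatter) and the step of a 9.5-fold lower number from compound 2 to compound 3 (0.98 log units; beyond the scatter) both lie beyond the scatter, and the step of a 4.1-fold higher number from compound 1 to compound 2 (0.61 log units; beyond the scatter) shows the carboxypropyl variant furthest from it. Compound 4 `CC(C)(C)OC(=O)N1CC[C@H](C(=O)N2CCC(NS(=O)(=O)c3cc(S(=O)(=O)c4ccccc4)ccc3C(F)(F)F)CC2)C1` keeps the same atoms as compound 3 but joins them differently: 1-(tert-butoxycarbonyl)pyrrolidin-3-yl in place of 1-(tert-butoxycarbonyl)pyrrolidin-2-yl on a carbonyl carbon. For the measured compounds named here, none of the measured steps exchanges one ring attachment point for another, so none bears directly on this change; the measured steps only show that the carbonyl substituent moves the result by modest amounts in this assay. A modest step in either direction is therefore expected for compound 4, with the estimated step being a 1.5-fold higher number from compound 3 to compound 4 (0.18 log units; within the scatter). Compound 4 is thus expected to give about 90 nM in this assay, within a range of 35 nM to 250 nM.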

Compound 4, half-maximal effective concentration: 150 nM
Compound 4: the middle estimate sits 1.7-fold (0.22 log units) below what was measured; the range from low to high includes it.
By their numbers in this assay, from the lowest: compound 3; then compounds 1 and 4 (each within the scatter of the next); then compound 2.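

Exchanging 1-(tert-butoxycarbonyl)pyrrolidin-2-yl for 1-(tert-butoxycarbonyl)pyrrolidin-3-yl leaves the atoms unchanged, yet it gives a 2.5-fold higher number from compound 3 to compound 4 (0.40 log units; beyond the scatter) in this assay, so on this carbonyl carbon the way the ring is joined counts by itself, and not only which atoms the group holds. The 1-(tert-butoxycarbonyl)pyrrolidin-3-yl and 6-chloropyridin-3-yl groups cannot be told apart here, at a 1.1-fold higher number from compound 1 to compound 4 (0.03 log units; within the scatter), while a 3.8-fold lower number from compound 2 to compound 4 (0.58 log units; beyond the scatter) shows that the 3-carboxypropyl group stays apart from the new group as well. Nothing available explains this shift between the two attachments.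

The compounds shown leave open whether the difference between the two attachments persists when a free pyrrolidine amine or an acetyl group replaces the tert-butoxycarbonyl group. They also leave open how the opposite stereoisomer of either ring would read.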